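A few compounds are considered here, and "the series" means these few. Any claim that something is new, unique, unknown or untested is made for them only; others in the source may bear on it.

Working notes on the series. Among the measured compounds shown here, compound 2 `O=P(O)(O)OCc1nc(Nc2ccc(C(F)(F)F)cc2)c2ccc(-c3ncccc3C(F)(F)F)cc2n1` is the higher of the two numbers measured so far in a functional assay for antagonist activity at transient receptor potential cation channel subfamily V member 1 (Homo sapiens) (a higher number here means a weaker inhibitor, a lower number a stronger inhibitor), where compound 2 gives 46 nM. For the measured compounds named here, its nearest neighbour is compound 1 `CCOCc1nc(Nc2ccc(C(F)(F)F)cc2)c2ccc(-c3ncccc3C(F)(F)F)cc2n1`, which in this assay gives 0.9 nM; the only measured step, a 51-fold higher number from compound 1 to compound 2 (1.71 log units; beyond the scatter), separates them.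

Compound 3 `OCCCc1nc(Nc2ccc(C(F)(F)F)cc2)c2ccc(-c3ncccc3C(F)(F)F)cc2n1` has not been measured. It differs from compound 2 by a group of 3 heavy atoms (2 carbon, 1 oxygen; no ring) in place of a group of 5 heavy atoms (4 oxygen, 1 phosphorus; no ring), on a saturated chain carbon bound to an aromatic carbon: what leaves carries two hydrogen-bond donors and two acceptors, what enters is a 2-hydroxyethyl with one of each, on a saturated chain carbon bound to an aromatic carbon.

The step that bears on it is a 51-fold higher number from compound 1 to compound 2 (1.71 log units; beyond the scatter), which shows that attaching the group of four heavy atoms on the oxygen of the saturated carbon raised the number strongly. Removing that group again in compound 3 is expected to reverse most of that rise, so a large drop toward the number of compound 1 is expected, a 15-fold lower number from compound 2 to compound 3 (1.19 log units; beyond the scatter). For compound 3 the estimate in this assay is 3 nM, with a range from 0.8 nM to 12 nM.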

Compound 3, half-maximal inhibitory concentration: 25 nM
Compound 3: the middle estimate sits 8.3-fold (0.92 log units) below what was measured; measured number above the stated range.
By their numbers in this assay, from the lowest: compound 1; then compounds 3 and 2 (each within the scatter of the next).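

Swapping the phosphorus-bearing group for 2-hydroxyethyl on a saturated chain carbon bound to an aromatic carbon gives a 1.8-fold lower number from compound 2 to compound 3 (0.26 log units; within the scatter), so in this assay the two groups cannot be told apart, and the high number of compound 2 is not specific to the group with phosphorus. The change from ethoxy to 2-hydroxyethyl at the same place gives a 28-fold higher number from compound 1 to compound 3 (1.44 log units; beyond the scatter), which shows that a group without phosphorus can also stand far from compound 1, and that this position responds strongly to a change of just a few atoms; among the three compounds, only compound 1 stands apart, with both of its steps beyond the scatter. Nothing available measures why ethoxy differs from the other two groups, so the numbers give no explanation.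

The compounds shown leave open whether the low number of compound 1 depends on the ether oxygen, which a comparison with a plain propyl chain or a methoxy group at this place would address. They also leave open how an amine or a carboxylic acid at this place would compare with 2-hydroxyethyl and with ethoxy.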